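Bromo for methyl on the aromatic ring of compound 2

The source may report more compounds than this note shows. Statements on the series, on what has been measured and on what is new or still open speak of the compounds shown alone.

Measured compounds:
compound 1 `CCO[C@H]1C[C@@H](c2coc3ccc(Br)cc3c2=O)N(c2ccccc2)O1` — > 60000 nM
compound 2 `Cc1ccc2occ([C@@H]3C[C@H](c4ccccc4)ON3c3ccccc3)c(=O)c2c1` — 31700 nM
compound 3 `Cc1ccc2occ([C@@H]3C[C@H](OCC(C)C)ON3c3ccccc3)c(=O)c2c1` — > 60000 nM

Going by the values given here, in a functional assay on Caco-2 cells (Homo sapiens) for inhibition, read by sulforhodamine B assay, with a stated time of 48 h (a lower number here means a stronger inhibitor, a higher number a weaker inhibitor), compound 2 gives 31700 nM, the only number among the three values shown. For compound 1 the result is a limit of the assay, > 60000 nM. For compound 3 the result is likewise a limit, > 60000 nM. Most of the set therefore sits at the limit of > 60000 nM in this assay, at which 2 of the 3 values shown sit.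

Among the compounds with values here, the one step between measured compounds that differ in a single place is an at least 1.8-fold higher number from compound 2 to compound 3 (0.27 log units; that floor lies within the scatter); the change there is isobutoxy in place of phenyl on a saturated ring carbon, and its floor lies within the scatter.

Compound 4 `O=c1c([C@@H]2C[C@H](c3ccccc3)ON2c2ccccc2)coc2ccc(Br)cc12` is not yet measured. It differs from compound 2 in one place: bromo in place of methyl on an aromatic carbon. Within the data shown here, no measured step covers this change. Among the measured compounds shown here, compound 1 carries bromo, but it also carries ethoxy where compound 2 carries phenyl, so its two values show only that compound 1 stops at a limit while compound 2 gives a number.

For the measured compounds named here, with no step bearing on the aromatic exchange, a step of a 1.1-fold higher number from compound 2 to compound 4 (0.04 log units; within the scatter) is expected, none beyond the scatter. Compound 4 is estimated at 35000 nM, between 14000 nM and 90000 nM, with a fair chance that this assay reports only a limit.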

Compound 4, half-maximal inhibitory concentration: > 60000 nM
Compound 4 ended at the assay's limit (the forecaster's own chance of this, stated with the estimate: 35%); middle value at least 1.7-fold (0.23 log units) away from the limit.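

In this assay compound 4 gives > 60000 nM, which is a limit of the assay and not a number. With phenyl kept on the saturated ring carbon, the exchange on the aromatic carbon can now be read alone: bromo in place of methyl gives an at least 1.8-fold higher number from compound 2 to compound 4 (0.27 log units; that floor lies within the scatter), so no real loss is established, though bromo no longer yields a number on this core, and the step linking compound 1 with compound 4 cannot be read. Phenyl on the saturated ring carbon is thus not enough by itself to give a number, and compound 2 remains the only compound that does, with the others sitting at one limit: the limit of > 60000 nM in this assay, at which 3 of the 4 values shown sit.

Still open, from the compounds shown here alone, is whether a different group on this aromatic carbon, such as chloro, methoxy or a carboxylic acid, would give a number at all, and whether any such group would improve on compound 2. Also open, going by these compounds, is whether an amine or a longer chain in place of phenyl on the saturated ring carbon would bring the series to a measurable value.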